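Replacing 4-methylphenyl in compound 3 with 3-methoxyphenyl

This account rests on a few compounds, and the source may have more. Where it says the series, first, only, none or still open, it means among the compounds named here.

compound 1 `CCNC(=S)N/N=C/c1cccc2ccccc12` gives 1100 nM
compound 2 `S=C(N/N=C/c1cccc2ccccc12)Nc1ccccc1` gives 500 nM
compound 3 `Cc1ccc(NC(=S)N/N=C/c2cccc3ccccc23)cc1` gives 580 nM

These numbers come from a functional assay on B16 cells (Mus musculus), read by spectrophotometry, with a stated time of 3 days (a higher number here means a weaker inhibitor, a lower number a stronger inhibitor), and compound 3 at 580 nM lies within the scatter of both other compounds. The change now in view puts 3-methoxyphenyl in place of 4-methylphenyl on an amide-type nitrogen and gives the unmeasured compound 4 `COc1cccc(NC(=S)N/N=C/c2cccc3ccccc23)c1` on the same core.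

Among the measured compounds shown here, three measured steps bear on this. Phenyl in place of ethyl gave a 2.2-fold lower number from compound 1 to compound 2 (0.34 log units; beyond the scatter) as a modest step, and 4-methylphenyl in place of ethyl gave a 1.9-fold lower number from compound 1 to compound 3 (0.28 log units; within the scatter) on the same nitrogen. Closest to the new change, methyl in place of hydrogen on an aromatic carbon gave a 1.2-fold higher number from compound 2 to compound 3 (0.06 log units; within the scatter) and so barely registers. For the measured compounds named here, no measured compound carries a methoxy group, so this guide is thin.

The expected change is a 1.1-fold lower number from compound 3 to compound 4 (0.05 log units; within the scatter) in this assay and that would be no step beyond the scatter. For compound 4 the estimate is 520 nM and the expected range runs from 230 nM up to 1150 nM at its two ends.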

Compound 4, half-maximal inhibitory concentration: 830 nM
Compound 4: middle estimate off by 1.6-fold (0.20 log units), on the low side; measured number inside the range.
By their numbers in this assay, from the lowest: compounds 2, 3, 4 and 1 (each within the scatter of the next, the first and the last beyond it).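

In this assay, 3-methoxyphenyl in place of 4-methylphenyl on this amide-type nitrogen gives a 1.4-fold higher number from compound 3 to compound 4 (0.16 log units; within the scatter) and adding methoxy to the phenyl group gives a 1.7-fold higher number from compound 2 to compound 4 (0.22 log units; within the scatter) while 3-methoxyphenyl in place of ethyl gives a 1.3-fold lower number from compound 1 to compound 4 (0.12 log units; within the scatter) so all three steps stay within the scatter. The first group shown here with an oxygen and a hydrogen-bond acceptor therefore does not separate compound 4 from any of the earlier compounds. Nothing measured here explains why these numbers stay so close.

The compounds shown leave open whether a phenyl ring carrying an amine or a carboxylic acid, or a longer chain in place of ethyl, would move the number beyond the scatter. Compound 3 and compound 4 differ in both the group and its place on the ring, so those two effects cannot be told apart.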